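Benzylamine side-chain variation on the shared core

The compounds below may be only part of what the source reports. "The series", "measured", "known", "first", "only" and "open" are said of these compounds alone.

Measured compounds:
compound 1 `OCCCNCc1nc2c(OCC3CCCCC3)cccc2[nH]1`: 28500 nM
compound 2 `CCCC(CO)NCc1nc2c(OCC3CCCCC3)cccc2[nH]1`: 7500 nM
compound 3 `OCCC(NCc1nc2c(OCC3CCCCC3)cccc2[nH]1)c1ccccc1`: 22000 nM

In an assay on cells for inhibition of interleukin-5 receptor subunit alpha (Mus musculus), read by WST assay, with a stated time of 48 h, in the presence of a further agent that is not named here (on this read-out lower numbers stand for stronger inhibition and higher numbers for weaker inhibition), compound 3 stands second highest of the three numbers, with compound 1 nearest and compound 2 furthest. Compound 4 `c1ccc(CNCc2nc3c(OCC4CCCCC4)cccc3[nH]2)cc1` differs from compound 3 by hydrogen in place of 2-hydroxyethyl on a saturated chain carbon bound to an amine nitrogen and an aromatic carbon. For the measured compounds named here, two measured steps bear on this. The change a 1.3-fold lower number from compound 1 to compound 3 (0.11 log units; within the scatter) shows that a phenyl on that carbon hardly moves the number. The change a 3.8-fold lower number from compound 1 to compound 2 (0.58 log units; beyond the scatter) shows that altering the hydroxyalkyl arm can shift the number modestly. Going by the values given here, no measured pair removes the hydroxyalkyl arm altogether, so the expectation is weak. The step of a 1.4-fold higher number from compound 3 to compound 4 (0.13 log units; within the scatter) is therefore expected to stay within the scatter, if anything toward a higher number. Compound 4 is estimated at 30000 nM, in the range 10000 nM to 90000 nM.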

Compound 4, half-maximal inhibitory concentration: > 30000 nM
Compound 4: a limit, no number; the forecaster's own chance of this, stated with the estimate: 15%; the middle value sits exactly at the limit.
By their numbers in this assay, from the lowest: compound 2; then compounds 3 and 1 (each within the scatter of the next). At a limit, above all of these: compound 4.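

For compound 4, > 30000 nM is a limit of the assay and not a number: the limit of > 30000 nM in this assay, at which 1 of the 4 values shown sits.

Removing the 2-hydroxyethyl gives no gain at this carbon, but the floors an at least 1.3-fold higher number from compound 3 to compound 4 (0.13 log units; that floor lies within the scatter) and an at least 1.0-fold higher number from compound 1 to compound 4 (0.02 log units; that floor lies within the scatter) fix no size for the change. Only an at least 4.0-fold higher number from compound 2 to compound 4 (0.60 log units; beyond the scatter) clears the scatter, so benzyl on the amine nitrogen does not match 1-(hydroxymethyl)butyl.

As far as these compounds go, how much the 2-hydroxyethyl contributes stays open without a number for compound 4. Also open, from the compounds shown here alone, is whether an amine or a carboxylic acid at the end of that arm, or a longer chain, would lower the number.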